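Swapping the aryl on the piperazine nitrogen for a pyridylmethyl

The compounds below may be only part of what the source reports. "The series", "measured", "known", "first", "only" and "open" are said of these compounds alone.

Measured so far:
- compound 1 `Nc1ccccc1NC(=O)c1ccc(CSC(=S)N2CCN(c3ccc(Cl)cc3)CC2)cc1`: 17.2%
- compound 2 `Nc1ccccc1NC(=O)c1ccc(CSC(=S)N2CCN(c3ccccc3)CC2)cc1`: 87.4%
- compound 3 `N#Cc1ccc(N2CCN(C(=S)SCc3ccc(C(=O)Nc4ccccc4N)cc3)CC2)cc1`: 37.6%

In a functional assay on MGC-803 cells (Homo sapiens) for antiproliferative activity, read by CCK-8 assay, with a stated time of 72 h, tested at 8 uM (on this read-out higher numbers stand for a stronger effect at the one concentration tested and lower numbers for a weaker effect), compound 3 gives 37.6%, the second highest of the three numbers. It sits beyond the scatter from both neighbours: a number 20.4 percentage points higher from compound 1 to compound 3 (beyond the scatter), while a number 49.8 percentage points lower from compound 2 to compound 3 (beyond the scatter).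

Compound 4 `Nc1ccccc1NC(=O)c1ccc(CSC(=S)N2CCN(Cc3ccncc3)CC2)cc1` has not been measured. It differs from compound 3 by (pyridin-4-yl)methyl in place of 4-cyanophenyl on an amine nitrogen in a ring.

Going by the values given here, no measured step changes the group on this ring nitrogen in this way; the known steps only exchange the substituent on the phenyl ring, and those steps were large, for example a number 70.2 percentage points higher from compound 1 to compound 2 (beyond the scatter). The group attached to this nitrogen has shifted the read-out strongly in the measured steps. A new group on it is expected to move the read-out again, but the direction is uncertain. The step of a number 12.4 percentage points higher from compound 3 to compound 4 (beyond the scatter) is the expected outcome. Compound 4 is estimated at 50% in this assay, with a range from 15% to 85%.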

Compound 4, a percentage reported as inhibition, at one concentration (the size of the read-out at that concentration, not a potency): 79.3%
Compound 4: the middle estimate sits 29.3 percentage points below what was measured; the measured number falls inside the stated range.
By their numbers in this assay, from the lowest: compound 1; then compound 3; then compounds 4 and 2 (each within the scatter of the next).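

At this ring nitrogen the aromatic ring need not be attached directly: in this assay the (pyridin-4-yl)methyl group gives a number 41.7 percentage points higher from compound 3 to compound 4 (beyond the scatter) and a number 62.1 percentage points higher from compound 1 to compound 4 (beyond the scatter) on the same core. Against the unsubstituted phenyl group there is a number 8.1 percentage points lower from compound 2 to compound 4 (within the scatter) so this read-out does not tell those two groups apart. No evidence here explains these steps. As far as these compounds go, what stays open is which part of the new group matters: a plain benzyl group on the same nitrogen would test the pyridine nitrogen, and a (pyridin-3-yl)methyl group would test its place in the ring.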